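The source may report more compounds than this note shows. Statements on the series, on what has been measured and on what is new or still open speak of the compounds shown alone.

Measured in a functional assay on HL-60 cells (Homo sapiens), with a stated time of 48 h; on this read-out lower numbers stand for an effect already at smaller amounts and higher numbers for an effect only at larger amounts of compound:
- Compound 1 `COc1ccc(/C=C\c2ccc3c(c2)C(C)(C)CCC3(C)C)cc1N`: 50000 nM
- Compound 2 `COc1ccc(/C=C/c2ccc3c(c2)C(C)(C)CCC3(C)C)cc1N`: 85000 nM
- Compound 3 `C/C(=C/c1cccc(C(=O)O)c1)c1ccc2c(c1)C(C)(C)CCC2(C)C`: 80000 nM

Compound 1 gives 50000 nM, and its gaps to compound 2 and compound 3 lie within the usual scatter, so the three stand level. Compound 4 `CC1(C)CCC(C)(C)c2cc(/C=C\c3cccc(N)c3)ccc21` differs from compound 1 in one place: hydrogen in place of methoxy on an aromatic carbon. In short, hydrogen takes the place of methoxy on an aromatic carbon. Within the data shown here, no measured step makes this change. Among the measured compounds shown here, the only step available, a 1.7-fold higher number from compound 1 to compound 2 (0.23 log units; within the scatter), concerns the configuration of the double bond, so it bears on the new change only indirectly. With so little to go on, no shift beyond the scatter is expected in this assay, and no direction can be given. The estimated step is a 1.1-fold higher number from compound 1 to compound 4 (0.04 log units; within the scatter). For compound 4 the expected value is 55000 nM, with an estimated range from 20000 nM to 120000 nM.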

Compound 4, concentration for half-maximal activity: 10000 nM
Beside the measured number, compound 4's estimate is 5.5-fold (0.74 log units) above it; measured number below the stated range.
By their numbers in this assay, from the lowest: compound 4; then compounds 1, 3 and 2 (each within the scatter of the next).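

Hydrogen in place of methoxy in this assay gives a 5.0-fold lower number from compound 1 to compound 4 (0.70 log units; beyond the scatter) and is the only step here that lies beyond the scatter. The place ortho to an amino group and para to a large group therefore matters on this read-out, and with hydrogen there, a smaller amount of compound gives the effect. Nothing shown here explains why this change has this effect.

On these data alone, whether a hydroxyl group or a fluorine atom at this place would also give a lower number remains open. So does whether the same change would act alike in the compound with the double bond drawn E, compound 2.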